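A few compounds are considered here, and "the series" means these few. Any claim that something is new, unique, unknown or untested is made for them only; others in the source may bear on it.

For the measured compounds named here, in an ADME assay on HepG2 cells (Homo sapiens) for cytotoxicity, with a stated time of 72 h (a lower number here means that less compound is needed, a higher number that more compound is needed for the effect), compound 1 `CC(=O)c1ccc(NC(=O)Nc2cc(C)nc3ccccc23)cc1` gives 19000 nM, the only true number in this small set. Compound 2 `Cc1ccc(NC(=O)Nc2cc(C)nc3ccccc23)cc1` is recorded only as a limit, > 25000 nM. Going by these compounds, compound 3 `Cc1cc(NC(=O)Nc2ccc(N(C)C)cc2)c2ccccc2n1` is also recorded only as a limit, > 25000 nM, so its real position is unknown. Compound 4 `Cc1cc(NC(=O)Nc2ccc(C(N)=O)cc2)c2ccccc2n1` has carbamoyl in place of dimethylamino on an aromatic carbon. The measured steps at this same place on the ring show an at least 1.3-fold higher number from compound 1 to compound 2 (0.11 log units; that floor lies within the scatter) and an at least 1.3-fold higher number from compound 1 to compound 3 (0.11 log units; that floor lies within the scatter), along with a step that the two limits leave unreadable from compound 2 to compound 3. None of them therefore shows a change beyond the scatter, and the picture is dominated by the limit of > 25000 nM in this assay, at which 2 of the 3 values shown sit. In this assay, no step beyond the scatter is expected for the new group, and a further limit is quite likely. The estimated outcome is a number no higher from compound 3 to compound 4 (the limit leaves the size open), which is not expected to be a clear shift. For compound 4 the expected value is 25000 nM, with an estimated range from 13000 nM to 45000 nM.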

Compound 4, half-maximal effective concentration: > 25000 nM
Compound 4: a limit, no number; the forecaster's own chance of this, stated with the estimate: 60%; the middle value sits exactly at the limit.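

In this assay compound 4 gives > 25000 nM, a limit and not a number, so a group with a hydrogen-bond donor at this place also fails to yield a true number. For the compounds shown here, replacing methyl with amino on the carbonyl carbon, the closest comparison with the one true number, gives an at least 1.3-fold higher number from compound 1 to compound 4 (0.11 log units; that floor lies within the scatter), so the carbonyl-bearing pair shows no change beyond the scatter. The steps from compound 2 and from compound 3 cannot be read, and the series still rests on a single number: the limit of > 25000 nM in this assay, at which 3 of the 4 values shown sit.

Going by these compounds, how far compound 2, compound 3 and compound 4 actually lie beyond their limits remains open. So does whether a carboxylic acid or a primary amine on this aromatic carbon would give a true number.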